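Working notes: from compound 1 to compound 4

This account rests on a few compounds, and the source may have more. Where it says the series, first, only, none or still open, it means among the compounds named here.

In a functional assay on SK-BR-3 cells (Homo sapiens) for antiproliferative activity, read by MTT assay, with a stated time of 72 h (a lower number here means a stronger inhibitor, a higher number a weaker inhibitor), compound 1 (`C/C=C1/[C@H](O[C@@H]2O[C@H](CO)[C@@H](O)[C@H](O)[C@H]2O)OC=C(C(=O)OC)[C@H]1CC(=O)OCc1ccco1`) gives > 15000 nM as a limit and not a number. Compound 2 (`C/C=C1/[C@H](O[C@@H]2O[C@H](COC(C)=O)[C@@H](OC(C)=O)[C@H](OC(C)=O)[C@H]2OC(C)=O)OC=C(C(=O)OC)[C@H]1CC(=O)O`) gives > 15000 nM as a limit too. Compound 3 (`C/C=C1/[C@H](O[C@@H]2O[C@H](COC(C)=O)[C@@H](OC(C)=O)[C@H](OC(C)=O)[C@H]2OC(C)=O)OC=C(C(=O)OC)[C@H]1CC(=O)OCCC1CCCCC1`) gives > 15000 nM as a limit too. All three sit at one limit (the limit of > 15000 nM in this assay, at which 3 of the 3 values shown sit). For the measured compounds named here, the only measured step, a step that the two limits leave unreadable from compound 2 to compound 3, has no readable size and is a different change. Compound 4 (`C/C=C1/[C@H](O[C@@H]2O[C@H](CO)[C@@H](O)[C@H](O)[C@H]2O)OC=C(C(=O)OC)[C@H]1CC(=O)OCC`) departs from compound 1 by methyl in place of furan-2-yl on a saturated chain carbon bound to an oxygen next to a carbonyl group with methyl in place of furan-2-yl. Going by the values given here, no measured step covers that change. With compound 1 showing only > 15000 nM as a limit, no gain beyond the scatter is expected in this assay and another limit is likely. The estimated step is a step that the limit leaves unreadable from compound 1 to compound 4 with no clear direction. For compound 4 the expected value is 20000 nM within an estimated range of 9000 nM to 45000 nM overall.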

Compound 4, half-maximal inhibitory concentration: > 15000 nM
Compound 4 gave a limit, no number; the forecaster's own chance of this, stated with the estimate: 85%; the middle value lies beyond the limit too.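

No new step can be read from compound 1 to compound 4, as both values are limits and not numbers: the limit of > 15000 nM in this assay, at which 4 of the 4 values shown sit.

The compounds shown leave open whether any change to the shared core gives a number rather than a limit in this assay.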